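This account rests on a few compounds, and the source may have more. Where it says the series, first, only, none or still open, it means among the compounds named here.

Measured compounds:
- compound 1 `COc1ccc(-c2nnc(SCC(=O)c3ccccc3)n2-c2ccccc2)cc1OC` gives 57% in a functional assay on the whole organism (strain albino) for inhibition, with Rattus norvegicus as the target, read by paw edema, with a stated time of 2 h, at a dose of 0.28 mmol/kg by the oral route; a higher number here means more inhibition at the dose given (going by the name of the read-out), a lower number less inhibition
- compound 2 `C=CCn1c(SC/C(=N/O)c2ccccc2)nnc1-c1ccc(OC)cc1` gives 66% in this assay
- compound 3 `COc1ccc(-c2nnc(SC/C(=N/O)c3ccccc3)n2-c2ccccc2)cc1OC` gives 61% in this assay

Compound 3 and compound 1 share a core and differ in one place: a group of 8 heavy atoms (7 carbon, 1 oxygen; one six-membered aromatic ring of carbon only) in place of a group of 9 heavy atoms (7 carbon, 1 nitrogen, 1 oxygen; one six-membered aromatic ring of carbon only), on a saturated chain carbon bound to a sulfur. The matching step is a number 4 percentage points lower from compound 3 to compound 1 (within the scatter). Compound 2 stands on a different core; how its core differs from that of compound 3 is not broken down here. Compound 2 reads highest of the three numbers, but both its gap to compound 3 and its gap to compound 1 lie within the scatter, so no order among the three is claimed.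

Compound 4 `C=CCn1c(SCC(=O)c2ccccc2)nnc1-c1ccc(OC)cc1` is not yet measured. It comes from compound 2 by the same change as that from compound 3 to compound 1: a group of 8 heavy atoms (7 carbon, 1 oxygen; one six-membered aromatic ring of carbon only) in place of a group of 9 heavy atoms (7 carbon, 1 nitrogen, 1 oxygen; one six-membered aromatic ring of carbon only), on a saturated chain carbon bound to a sulfur. The place of the change is the same in both pairs, a saturated chain carbon bound to a sulfur; what differs is only the core that carries it.

In this assay, going by the values given here, the expected step is a number 4 percentage points lower from compound 2 to compound 4 (within the scatter), because a number 4 percentage points lower from compound 3 to compound 1 (within the scatter) was within the scatter on the other core, and nothing among the measured compounds suggests a larger shift. Compound 4 is therefore expected to give 62%, with a range from 50% to 73%. Among the compounds with values here, this rests on a single earlier instance of the change, and the core of compound 2 has no second measured pair to check it against.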

Compound 4, a percentage reported as inhibition, in the whole organism at one dose (the size of the read-out at that dose, not a potency): 53%
Estimate against measurement, compound 4: 9 percentage points above, and the stated range covers the measured number.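

In this assay, putting benzoyl in place of the group of 9 heavy atoms, on a saturated chain carbon bound to a sulfur, gives a number 13 percentage points lower from compound 2 to compound 4 (beyond the scatter). Set beside the earlier instance of the same change, this step cannot be told apart from it, so the two cores give no sign that the change behaves differently from one to the other: the same change on two cores in this assay, a number 4 percentage points lower (within the scatter) from compound 3 to compound 1 and a number 13 percentage points lower (beyond the scatter) from compound 2 to compound 4, 9 percentage points apart, within the scatter of two such steps This does not show that the step is the same on both cores, nor that the core of compound 2 responds more strongly, even though only the step on that core lies beyond the scatter; with a single pair per core, no common size for the step can be given, and the data say nothing on why the numbers move.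

Open, from the compounds shown here alone, is how the paw edema read-out responds when an amine or a carboxylic acid stands in place of benzoyl, or when a longer chain carries the benzoyl group. Also open, going by these compounds, is whether the step seen here would hold on a third core, or at another dose or time, since a further pair would be needed to fix its size.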